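Amide replacement on the histamine H3 series

This account rests on a few compounds, and the source may have more. Where it says the series, first, only, none or still open, it means among the compounds named here.

Measured compounds:
compound 1 `Cc1cc(NC(=O)C2CC3CCC2C3)ccc1N1CCC(N2CCCC2C)C1` — 130 nM
compound 2 `Cc1cc(N2CCC(N3CCCC3C)C2)ccc1NC(=O)C1CCOCC1` — 6.8 nM
compound 3 `Cc1cc(N2CC[C@@H](N3CCC[C@@H]3C)C2)ccc1NC(=O)C1CCOCC1` — 3.9 nM

All three were run in an assay on CHO cells for displacement of a labelled ligand from histamine receptor H3 (Macaca mulatta); a lower number here means a stronger inhibitor, a higher number a weaker inhibitor. Compound 1 gives the highest number of the three; compound 2 and compound 3 both give markedly lower numbers, both gaps lying well beyond the scatter. Within the data shown here, the only one-place step measured so far is a 1.7-fold lower number from compound 2 to compound 3 (0.24 log units; within the scatter), which is within the scatter; what separates these two is only (the fact that one of compounds 2 and 3 is drawn with a defined configuration and the other without, at the place where they differ), so nothing firm follows from it about the amide portion.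

Compound 4 `CC(=O)N1CCCC1C(=O)Nc1ccc(N2CCC(N3CCCC3C)C2)c(C)c1` is the next target. It departs from compound 1 at the carbonyl carbon: a group of 8 heavy atoms (6 carbon, 1 nitrogen, 1 oxygen; one five-membered non-aromatic ring with 1 hetero atom) in place of a group of 7 heavy atoms (7 carbon; 2 five-membered non-aromatic rings of carbon only), on a carbonyl carbon. Among the measured compounds shown here, no measured step bears directly on this change. For the measured compounds named here, the only evidence from the series is indirect: the two compounds carrying an oxygen-containing saturated ring on the amide, compound 2 and compound 3, give much lower numbers than compound 1, which carries an all-carbon bicyclic group there, though those pairs are not one-place steps. On that basis a downward move is expected for compound 4, of moderate size, a 2.6-fold lower number from compound 1 to compound 4 (0.41 log units; beyond the scatter), with wide uncertainty. The expected value for compound 4 is 50 nM, ranging from 12 nM to 220 nM.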

Compound 4, inhibition constant: 44.9 nM
Compound 4: the middle estimate sits 1.1-fold (0.05 log units) above what was measured; the range from low to high includes it.
By their numbers in this assay, from the lowest: compounds 3 and 2 (each within the scatter of the next); then compound 4; then compound 1.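

Among these compounds, on the carbonyl carbon of the core of compound 1, the change from the all-carbon bicyclic group to 1-acetylpyrrolidin-2-yl gives the first direct reading at this position: in this assay there is a 2.9-fold lower number from compound 1 to compound 4 (0.46 log units; beyond the scatter), a modest move that lies beyond the scatter. Unlike the earlier comparisons with compound 2 and compound 3, this is a one-place step, so it shows that a group with a ring nitrogen and a hydrogen-bond acceptor can stand on this carbonyl carbon without raising the number, although the ring, the nitrogen and the acetyl carbonyl all change together and the step cannot be divided among them. Among the compounds shown here, nothing measured explains the size or direction of this step, and the only available evidence concerns a different pair of compounds.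

Going by these compounds, what remains open is which part of the entering group carries the step: pyrrolidin-2-yl without the acetyl, or a plain cyclopentyl on the same carbonyl carbon, would separate the ring nitrogen from the acetyl group. Compound 4 is also drawn without a defined configuration at its pyrrolidin-2-yl carbon, so the separate contributions of its R and S forms remain unresolved.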